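This account rests on a few compounds, and the source may have more. Where it says the series, first, only, none or still open, it means among the compounds named here.

Measured compounds:
- compound 1, `Cc1ccc2[nH]c(=O)c(/C=N/c3ccc(O)cc3)cc2c1`: 88500 nM
- compound 2, `O=c1[nH]c2ccccc2cc1/C=N/c1ccc(O)cc1`: 92100 nM

In a functional assay, read by spectrophotometry, with a stated time of 30 min (on this read-out lower numbers stand for stronger inhibition and higher numbers for weaker inhibition), compound 2 gives the highest of the two numbers; its nearest neighbour is compound 1, and the step of a 1.0-fold higher number from compound 1 to compound 2 (0.02 log units; within the scatter) lies within the scatter. Compound 3, `O=C(O)c1ccc(/N=C/c2cc3ccccc3[nH]c2=O)cc1`, differs from compound 2 by carboxy in place of hydroxy on an aromatic carbon. Going by the values given here, no measured step bears on this change; the only step, a 1.0-fold higher number from compound 1 to compound 2 (0.02 log units; within the scatter), concerns a different position and was flat. The expected step of a 1.0-fold lower number from compound 2 to compound 3 (0.00 log units; within the scatter) is therefore set at none beyond the scatter, with a wide range. Compound 3 is expected to give 92000 nM in this assay, between 30000 nM and 300000 nM.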

Compound 3, half-maximal inhibitory concentration: 1660000 nM
For compound 3 the middle estimate is 18-fold (1.26 log units) below the measured one; the whole stated range lies below it.
By their numbers in this assay, from the lowest: compounds 1 and 2 (each within the scatter of the next); then compound 3.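

In this assay, carboxy in place of hydroxy on the aromatic carbon para to a large group gives an 18-fold higher number from compound 2 to compound 3 (1.26 log units; beyond the scatter), so inhibition at this position responds strongly to the change. Going by these compounds alone, the only earlier step, a 1.0-fold higher number from compound 1 to compound 2 (0.02 log units; within the scatter), concerned a different position and stayed within the scatter. Nothing measured here accounts for the loss.

Going by these compounds, whether an amine, a methoxy group or a methyl ester at this position would stay level with compound 2 remains open. Also open, on these data alone, is whether the carboxy step would be the same size with the methyl group of compound 1 on the core.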